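Methoxymethoxy Becoming Methoxy on the Shared Core

The source may hold more compounds than are shown below. What is called first, only, known or untested is meant among the compounds shown, and "the series" means these compounds.

In a functional assay on MIA PaCa-2 cells (Homo sapiens) for cytotoxicity, read by resazurin assay, with a stated time of 72 h (on this read-out lower numbers stand for stronger inhibition and higher numbers for weaker inhibition), compound 1 (`COCOc1cc(OC)cc(OC)c1C(C)=O`) stands at > 20000 nM and this is a limit of the assay, not a number. Compound 2 (`COCOc1cc(OC)cc(OC)c1C(=O)/C=C/c1ccccc1`) gives 5600 nM while compound 3 (`COCOc1cc(OCOC)c(C(=O)/C=C/c2ccccc2)c(OCOC)c1`) gives 11800 nM and so holds the higher of the two actual numbers.

Compound 4 (`COCOc1cc(OC)c(C(=O)/C=C/c2ccccc2)c(OCOC)c1`) has not yet been measured. Its difference from compound 3 is hydrogen in place of methoxy on a saturated chain carbon bound to an oxygen on an aromatic ring and it amounts to methoxymethoxy becoming methoxy, on a saturated chain carbon bound to an oxygen on an aromatic ring.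

Within the data shown here, the only measured step is an at least 3.5-fold lower number from compound 1 to compound 2 (0.55 log units; beyond the scatter) and it is read against the limit of > 20000 nM in this assay, at which 1 of the 3 values shown sits, as its reference. That step puts 2-phenylethenyl in place of methyl on a carbonyl carbon, so it gives no direct measure of the present change. The nearer guide is a comparison of values. Compound 4 carries both methoxymethoxy and methoxy groups, which places it structurally between compound 2 at 5600 nM and compound 3 at 11800 nM on the numbers.

The estimated change is a 1.5-fold lower number from compound 3 to compound 4 (0.17 log units; within the scatter) and it is expected to stay within the scatter. The expected value for compound 4 is 8000 nM with an estimated range from 4000 nM to 16000 nM as its span.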

Compound 4, half-maximal inhibitory concentration: 2200 nM
Compound 4: middle estimate off by 3.6-fold (0.56 log units), on the high side, and the stated range ends above it.
By their numbers in this assay, from the lowest: compound 4; then compound 2; then compound 3. At a limit, above all of these: compound 1.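

In this assay, among these compounds, methoxymethoxy becoming methoxy, on a saturated chain carbon bound to an oxygen on an aromatic ring, gives a 5.4-fold lower number from compound 3 to compound 4 (0.73 log units; beyond the scatter) and so shows for the first time that this exchange of groups can move the number beyond the scatter. The reverse exchange, made at a different place on the shared core, gives a 2.5-fold lower number from compound 2 to compound 4 (0.41 log units; beyond the scatter) and so runs the other way: here methoxymethoxy in place of methoxy goes with the lower number. Among the three compounds that carry 2-phenylethenyl, the effect of this exchange therefore depends on where it is made, and compound 4, with one methoxy and two methoxymethoxy groups, holds the lowest number of the three.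

The compounds shown leave open how a hydroxy group, an ethoxy group or a longer chain would read at these places on the shared core. Nothing measured here bears on why the same exchange of groups moves the number in opposite directions at the two places.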